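A few compounds are considered here, and "the series" means these few. Any claim that something is new, unique, unknown or untested is made for them only; others in the source may bear on it.

Compound 1 `CC1CCN(c2nc(=O)c3cc([N+](=O)[O-])cc([N+](=O)[O-])c3s2)CC1` — in an ADME assay on Vero cells (Chlorocebus sabaeus) for cytotoxicity, read by MTT assay, with a stated time of 72 h (a higher number here means a weaker inhibitor, a lower number a stronger inhibitor), compound 1 stands at "not determined" (no result reported)
Compound 2 `CC(C)(C)OC(=O)N1CCN(c2nc(=O)c3cc([N+](=O)[O-])cc([N+](=O)[O-])c3s2)CC1` — in this assay compound 2 stands at "not determined" (no result reported)
Compound 3 `CCNc1nc(=O)c2cc(C(F)(F)F)cc([N+](=O)[O-])c2s1` — in this assay compound 3 stands at > 100000 nM, which is a limit of this assay and not a number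

Of the three compounds sharing the same core, only compound 3 carries a result, and that result is a limit rather than a measured number. For the measured compounds named here, compound 3 therefore stands at the edge of what this assay reports, with no second measured compound beside it: no step between measured compounds exists here to learn from.

Compound 4 `O=c1nc(N2CCCCC2)sc2c([N+](=O)[O-])cc(C(F)(F)F)cc12` differs from compound 3 in one place: piperidin-1-yl in place of ethylamino on an aromatic carbon. Going by the values given here, with no measured step to lean on, the expectation is that this change shifts the reading little, if at all, beyond the usual scatter, so compound 4 is expected to sit close to the limit of > 100000 nM in this assay, at which 1 of the 3 values shown sits. The estimated step is a step that the limit leaves unreadable from compound 3 to compound 4. Compound 4 is expected to give about 120000 nM, somewhere between 40000 nM and 300000 nM.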

Compound 4, half-maximal inhibitory concentration: > 100000 nM
Compound 4 ended at the assay's limit; the forecaster's own chance of this, stated with the estimate: 70%; the middle value lies beyond the limit too.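

Compound 3 and compound 4 both end at a limit in this assay, not at a number, and no step can be read from piperidin-1-yl in place of ethylamino. Whether any change on the shared core would give a measurable reading stays open: the limit of > 100000 nM in this assay, at which 2 of the 4 values shown sit.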